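The source may report more compounds than this note shows. Statements on the series, on what has been measured and on what is new or still open speak of the compounds shown alone.

In an ADME assay on Vero cells (Chlorocebus sabaeus) for cytotoxicity, read by MTT assay, with a stated time of 96 h (a higher number here means that more compound is tolerated, a lower number that less compound is tolerated), compound 1 `C/C(=N\NC(N)=S)c1ccc2[nH]c(-c3ccccc3)nc2c1` gives > 100000 nM, which is a limit of the assay and not a number. Compound 2 `CC(=O)c1ccc2c(c1)nc(-c1ccccc1)n2C1CCCCC1` gives 80000 nM, and compound 3 `C/C(=N\NC(N)=S)c1ccc2c(c1)nc(-c1ccccc1)n2C1CCCCC1` gives 20000 nM, the lowest number among those shown. Compound 4 `C/C(=N\NC(N)=S)c1ccc2c(c1)nc(-c1ccccn1)n2C1CCCCC1` differs from compound 3 by one swap, (pyridin-2-yl in place of phenyl on an aromatic carbon), with pyridin-2-yl in place of phenyl on an aromatic carbon. The measured steps, an at least 5.0-fold lower number from compound 1 to compound 3 (0.69 log units; beyond the scatter) and a 4.0-fold lower number from compound 2 to compound 3 (0.60 log units; beyond the scatter), lie beyond the scatter, but both changed other groups and left the phenyl in place, so neither gives a size for this swap. Compound 3 at 20000 nM therefore remains the best guide. The expected step is a 1.3-fold higher number from compound 3 to compound 4 (0.10 log units; within the scatter), which would stay within the scatter. For compound 4 the estimated value is 25000 nM, with an expected range from 10000 nM to 60000 nM.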

Compound 4, half-maximal cytotoxic concentration: 20000 nM
Estimate against measurement, compound 4: 1.3-fold (0.10 log units) above, within the range that was stated.
By their numbers in this assay, from the lowest: compounds 3 and 4 (each within the scatter of the next); then compound 2. At a limit, above all of these: compound 1.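

In this assay, going by these compounds alone, no change at the digits printed from compound 3 to compound 4 (within the scatter) shows that this position, on an aromatic carbon between two ring nitrogen atoms, accepts pyridin-2-yl for phenyl with no step beyond the scatter, which the earlier compounds, all phenyl here, could not show. Only compound 1 stands at a limit of the assay, not at a number, so this step is read between two numbers: the limit of > 100000 nM in this assay, at which 1 of the 4 values shown sits.

The compounds shown leave open whether an amine or a carboxylic acid on this ring would read the same. They also leave open how a saturated ring such as piperidine would read at this position.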